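Swapping the ring on the core: a lipophilicity forecast

A few compounds are considered here, and "the series" means these few. Any claim that something is new, unique, unknown or untested is made for them only; others in the source may bear on it.

Measured compounds:
compound 1 `CCc1ccc(N(CC(C)C)S(=O)(=O)c2ccc3c(c2)C(=O)CC(C2(C)CCOCC2)O3)cc1` 4.71
compound 2 `CCS(=O)(=O)c1ccc(CNS(=O)(=O)c2ccc3c(c2)C(=O)CC(C2CCOCC2)O3)nc1` 0.32
compound 3 `CC(C)CN(c1ccc(N(C)C)cc1)S(=O)(=O)c1ccc2c(c1)C(=O)CC(C1CCOCC1)O2` 3.6

In a physicochemical assay for lipophilicity, at pH 7.4 (a lower number here means a more polar compound, a higher number a more lipophilic compound), compound 1 gives the highest of the three numbers. Compound 3 comes nearest, with a value a fair distance lower, and compound 2 lies far below both, each gap beyond the usual scatter.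

Compound 4 `CCc1ccc(N(CC(C)C)S(=O)(=O)c2ccc3c(c2)C(=O)CC(C2CCN(S(C)(=O)=O)CC2)O3)cc1` has not yet been measured. It differs from compound 1 in one place: 1-(methylsulfonyl)piperidin-4-yl in place of 4-methyloxan-4-yl on a saturated ring carbon. Among the measured compounds shown here, no measured pair shows this exact change, so its effect must be estimated. The expectation is a clear drop in this assay, well beyond the scatter, with an expected step of a number 1.41 log units lower from compound 1 to compound 4 (beyond the scatter). Compound 4 is therefore expected to give about 3.3, within a range from 2.7 to 3.9.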

Compound 4, distribution coefficient: 3.31
Compound 4: the middle estimate sits 0.01 log units below what was measured; low and high end bracket the measured number.
By their numbers in this assay, from the lowest: compound 2; then compounds 4 and 3 (each within the scatter of the next); then compound 1.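

In this assay, among the compounds shown here, the swap of 4-methyloxan-4-yl for 1-(methylsulfonyl)piperidin-4-yl gives the first step at this saturated ring carbon that changes only one place (a number 1.40 log units lower from compound 1 to compound 4 (beyond the scatter)). For the compounds shown here, the earlier compounds differ in more than one place, so only this pair shows that the group here can, on its own, move the number by a large amount. No measurement shown explains the size of this step. On these data alone, the step replaces the whole ring group at once, so the separate shares of the methyl, the ring nitrogen and the methylsulfonyl stay open. As far as these compounds go, how an amine or a carboxylic acid on this carbon would compare also stays open.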